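This account rests on a few compounds, and the source may have more. Where it says the series, first, only, none or still open, it means among the compounds named here.

Working notes on the series. Compound 1 `COc1cccc(CNCCCNc2ccnc3cc(-c4ccc(C(F)(F)F)cc4)ccc23)c1O` gives 9.47 in a physicochemical assay for acid dissociation. Compound 2 `COc1cccc(CNCCCNc2ccnc3cc(Cc4ccc(C#N)cc4)ccc23)c1O` gives 9.47. Compound 3 `COc1cccc(CNCCCNc2ccnc3cc(-c4ccc(F)cc4)ccc23)c1O` gives 9.47. Compound 3 thus stands level with both others in this assay: the steps of no change at the digits printed from compound 1 to compound 3 (within the scatter), no change at the digits printed from compound 2 to compound 3 (within the scatter) and no change at the digits printed from compound 1 to compound 2 (within the scatter) all lie within the scatter. Compound 4 `COc1cccc(CNCCCNc2ccnc3cc(Cc4ccc(F)cc4Cl)ccc23)c1O` differs from compound 3 only at the same position, (2-chloro-4-fluorobenzyl in place of 4-fluorophenyl on an aromatic carbon). The relevant measured steps, which exchanged aryl for benzyl and changed the substituent at this position, were flat, so for compound 4 the expected step is no change at the digits printed from compound 3 to compound 4 (within the scatter), with no change beyond the scatter. Compound 4 is therefore estimated at 9.47 in this assay, within 9.2 to 9.75.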

Compound 4, acid dissociation constant: 9.47
Compound 4: middle estimate and measured number agree at the digits printed, within the range that was stated.
By their numbers in this assay, from the lowest: compounds 1, 2, 3 and 4 (each within the scatter of the next).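

In this assay, chlorine enters at this position for the first time among the compounds shown, as part of 2-chloro-4-fluorobenzyl, and the read-out stays level (no change at the digits printed from compound 3 to compound 4 (within the scatter)). The same holds against the 4-cyanobenzyl and 4-(trifluoromethyl)phenyl groups (no change at the digits printed from compound 2 to compound 4 (within the scatter); no change at the digits printed from compound 1 to compound 4 (within the scatter)), so all three comparisons leave this position flat. Nothing available accounts for this flatness.

Every group shown here at this position is an aryl or benzyl group without an ionisable atom. As far as these compounds go, whether an amine or a carboxylic acid at this position, or a longer chain in the shared core, would shift the number remains open.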